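Moving the hydroxyl around the anilino ring

A few compounds are considered here, and "the series" means these few. Any claim that something is new, unique, unknown or untested is made for them only; others in the source may bear on it.

compound 1 `Fc1cccc(-c2nc(Nc3ccc(Br)cc3)c3cc(F)ccc3n2)c1`: in a functional assay on U-937 cells (Homo sapiens) for cytotoxicity, read by MTT assay, with a stated time of 48 h (on this read-out higher numbers stand for weaker inhibition and lower numbers for stronger inhibition), compound 1 gives > 50000 nM, a limit of the assay.
compound 2 `Fc1cccc(-c2nc(Nc3ccccc3Br)c3cc(F)ccc3n2)c1`: in this assay compound 2 gives > 50000 nM, a limit of the assay.
compound 3 `Oc1cccc(Nc2nc(-c3cccc(F)c3)nc3ccc(F)cc23)c1`: in this assay compound 3 gives > 50000 nM, a limit of the assay.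

Compound 3 therefore stands where every measured compound stands, at the limit of > 50000 nM in this assay, at which 3 of the 3 values shown sit. Compound 4 `Oc1ccccc1Nc1nc(-c2cccc(F)c2)nc2ccc(F)cc12` differs from compound 3 in one place: 2-hydroxyphenyl in place of 3-hydroxyphenyl on a nitrogen on an aromatic ring. The measured steps that touch the same position, a step that the two limits leave unreadable from compound 1 to compound 3 and a step that the two limits leave unreadable from compound 2 to compound 3, run between two limits and give neither size nor direction. No readable change is expected for compound 4, so the estimated step is a step that the limit leaves unreadable from compound 3 to compound 4. For compound 4 the expected result in this assay is 60000 nM, with a range from 20000 nM to 200000 nM, most probably again reported only as a limit.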

Compound 4, half-maximal inhibitory concentration: 46300 nM
Estimate against measurement, compound 4: 1.3-fold (0.11 log units) above; the measured number falls inside the stated range.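

In this assay, within the data shown here, 2-hydroxyphenyl in place of 3-hydroxyphenyl gives compound 4 the only reading here that is not a limit, but the change can be stated only as an at least 1.0-fold lower number from compound 3 to compound 4 (0.03 log units; that floor lies within the scatter). The other two changes read alike: hydroxy in place of bromo gives an at least 1.0-fold lower number from compound 2 to compound 4 (0.03 log units; that floor lies within the scatter), and 2-hydroxyphenyl in place of 4-bromophenyl gives an at least 1.0-fold lower number from compound 1 to compound 4 (0.03 log units; that floor lies within the scatter). The steps among the other three compounds cannot be read, as each sits at a limit: the limit of > 50000 nM in this assay, at which 3 of the 4 values shown sit.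

Still open, going by these compounds, is how far the true gaps reach, and whether 4-hydroxyphenyl, or an amine or a carboxylic acid on this ring, would give a clearly lower number.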